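The compounds below may be only part of what the source reports. "The series", "measured", "known", "first", "only" and "open" are said of these compounds alone.

Measured so far:
compound 1 `CCSCCC12CCC(c3nnc(-c4ccccc4C(F)(F)F)n3C)(CC1)CC2`: 79%
compound 2 `Cn1c(-c2ccccc2C(F)(F)F)nnc1C12CCC(CCCC(C)(F)F)(CC1)CC2`: 99%

Among the measured compounds shown here, in a functional assay on the whole organism (strain ICR) for inhibition, with Mus musculus as the target, with a stated time of 4 h, at a dose of 10 mg/kg by the oral route (on this read-out lower numbers stand for less inhibition and higher numbers for more inhibition at the one dose given (going by the name of the read-out)), compound 2 stands highest of the two numbers; the one measured step, a number 20 percentage points higher from compound 1 to compound 2 (beyond the scatter), lies beyond the scatter. Compound 3 `CC(C)S(=O)(=O)CCC12CCC(c3nnc(-c4ccccc4C(F)(F)F)n3C)(CC1)CC2` differs from compound 2 by isopropylsulfonyl in place of 2,2-difluoropropyl on a saturated chain carbon, two bonds along the chain from a saturated ring carbon. For the measured compounds named here, no measured step swaps 2,2-difluoropropyl for isopropylsulfonyl, so the bearing of that step is indirect: it only shows that a change at this place can move the read-out. Compound 2 sits near the top of the scale, so little room remains upward. The expected step is a number 14 percentage points lower from compound 2 to compound 3 (beyond the scatter). Compound 3 is therefore estimated at 85%, between 60% and 100%.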

Compound 3, a percentage reported as inhibition, in the whole organism at one dose (the size of the read-out at that dose, not a potency): 88%
Compound 3: the middle estimate sits 3 percentage points below what was measured, within the range that was stated.
By their numbers in this assay, from the lowest: compounds 1 and 3 (each within the scatter of the next); then compound 2.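

In this assay the move from 2,2-difluoropropyl to isopropylsulfonyl at this place on the chain gives a number 11 percentage points lower from compound 2 to compound 3 (beyond the scatter) and thus shows that a sulfonyl group does not hold the level of compound 2. Set against ethylsulfanyl, isopropylsulfonyl gives a number 9 percentage points higher from compound 1 to compound 3 (within the scatter) and so cannot be told apart from it here. Nothing available explains what these groups do at this place. From the compounds shown here alone, whether an amine or a carboxylic acid on this chain would hold the read-out stays open, as does the effect of a longer chain.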